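From dimethylcarbamoyl to diethylcarbamoyl on a shared core

The source may report more compounds than this note shows. Statements on the series, on what has been measured and on what is new or still open speak of the compounds shown alone.

Compound 1 `COC/C1=C/C[C@](C)(CCC=C(C)C)/C=C/[C@@H](OC(=O)C=C(C)C)[C@](C)(O)/C=C/C1=O` gives 3850 nM
Compound 2 `CC(C)=CCC[C@]1(C)/C=C/[C@@H](OC(=O)C=C(C)C)[C@](C)(O)/C=C/C(=O)/C(CN=[N+]=[N-])=C\C1` gives 4230 nM
Compound 3 `CC(C)=CCC[C@]1(C)/C=C/[C@@H](OC(=O)C=C(C)C)[C@](C)(O)/C=C/C(=O)/C(C(=O)N(C)C)=C\C1` gives 3300 nM

All three values come from a functional assay on SW480 cells (Homo sapiens) for antiproliferative activity, read by MTT assay, with a stated time of 48 h (on this read-out lower numbers stand for stronger inhibition and higher numbers for weaker inhibition), and they form one tight group. Compound 3 stands level with the other two, as the steps of a 1.2-fold lower number from compound 1 to compound 3 (0.07 log units; within the scatter) and a 1.3-fold lower number from compound 2 to compound 3 (0.11 log units; within the scatter) show. Neither step separates it from the others.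

Compound 4 `CCN(CC)C(=O)/C1=C/C[C@](C)(CCC=C(C)C)/C=C/[C@@H](OC(=O)C=C(C)C)[C@](C)(O)/C=C/C1=O` has not yet been measured. It differs from compound 3 by a single change, diethylamino in place of dimethylamino on a carbonyl carbon. For the measured compounds named here, no measured step makes this exact change, so the evidence is indirect. The two steps above, together with a 1.1-fold higher number from compound 1 to compound 2 (0.04 log units; within the scatter), each exchange the group on the same double-bonded ring carbon, and none of them goes beyond the scatter. The change in compound 4 is also a smaller one, since the dimethylcarbamoyl and diethylcarbamoyl groups differ only in their chains.

On this basis, no step beyond the scatter is expected in this assay, and no direction can be favoured. The estimated step is a 1.1-fold higher number from compound 3 to compound 4 (0.03 log units; within the scatter) and it remains an expectation. For compound 4 the expected value is 3500 nM with an estimated range from 1800 nM to 6500 nM in repeated measurements.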

Compound 4, half-maximal inhibitory concentration: 11700 nM
For compound 4 the middle estimate is 3.3-fold (0.52 log units) below the measured one, outside the stated range (above it).
By their numbers in this assay, from the lowest: compounds 3, 1 and 2 (each within the scatter of the next); then compound 4.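

In this assay, methoxymethyl, azidomethyl and dimethylcarbamoyl on the double-bonded ring carbon of the shared core had given no step beyond the scatter, so this position had seemed to accept each of these groups alike. Compound 4 shows that it does not accept every change there: diethylamino in place of dimethylamino on the carbonyl carbon, a change confined to the chains on the amide nitrogen, gives a 3.5-fold higher number from compound 3 to compound 4 (0.55 log units; beyond the scatter), and compound 4 also separates from the other two, with a 2.8-fold higher number from compound 2 to compound 4 (0.44 log units; beyond the scatter) and a 3.0-fold higher number from compound 1 to compound 4 (0.48 log units; beyond the scatter). Nothing measured here bears on why the diethylamino group gives the higher number.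

The compounds shown do not tell whether the number keeps rising with a longer chain such as dipropylamino, or whether a single ethyl and a single methyl on the amide nitrogen already give part of this step. They also leave open how a ring amine such as pyrrolidine or morpholine would behave on the same carbonyl carbon, and how a secondary amide carrying one ethyl chain would compare.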